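A few compounds are considered here, and "the series" means these few. Any claim that something is new, unique, unknown or untested is made for them only; others in the source may bear on it.

Working notes on the series. Compound 1 `CCc1cc(-c2ccc(F)cc2)c(O)cc1OCCCOc1cccc(OC)c1CCC(=O)O` and compound 2 `CCCc1c(OCCCOc2cc(O)c(-c3ccc(F)cc3)cc2CC)ccc2c1OC(C(=O)O)CC2` share a core carrying a fluorophenyl group and a propyl-linked second aromatic part, and both have been measured in an assay on isolated protein for binding affinity to leukotriene B4 receptor (Homo sapiens); a lower number here means a stronger inhibitor, a higher number a weaker inhibitor. In this assay compound 1 gives 8.3 nM, while compound 2 gives 3.8 nM. Of these two numbers, compound 1 holds the higher one; the number for compound 2 is lower by an amount beyond the usual scatter, so compound 2 is the stronger inhibitor of the two. No single-point comparison between compound 1 and compound 2 is available, as they differ in more than one place, so nothing more is read from that pair.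

Compound 3 `CCc1cc(-c2ccc(F)cc2)c(O)cc1OCCCOc1cccc(CCCCC(=O)O)c1CCC(=O)O` is not yet measured. It departs from compound 1 in one place: 4-carboxybutyl in place of methoxy on an aromatic carbon. No comparable replacement of a methoxy group by a carboxyalkyl chain exists among the measured compounds, so the size and direction of the effect are open. As a working expectation, a small loss of affinity is assumed, with the step from compound 1 to compound 3 estimated at a 1.6-fold higher number from compound 1 to compound 3 (0.19 log units; within the scatter). Compound 3 is therefore expected to give about 13 nM in this assay, with a plausible range from 3 nM to 55 nM.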

Compound 3, inhibition constant: 2.3 nM
For compound 3 the middle estimate is 5.7-fold (0.75 log units) above the measured one; the whole stated range lies above it.
By their numbers in this assay, from the lowest: compounds 3 and 2 (each within the scatter of the next); then compound 1.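

On an aromatic carbon of the six-membered ring, ortho to a 2-carboxyethyl group, replacing methoxy with 4-carboxybutyl gives a 3.6-fold lower number from compound 1 to compound 3 (0.56 log units; beyond the scatter) in this assay. For the compounds shown here, this is the first reading at this position, and it shows that the position tolerates a much larger group, with 7 heavy atoms entering and 2 leaving, and that the binding number falls beyond the scatter rather than rising. The change also adds a second chain ending in a carboxylic acid to the core of compound 1, but nothing on hand indicates which feature of the 4-carboxybutyl group accounts for the step.

This single step does not separate the contribution of chain length from that of the terminal acid, so a plain pentyl chain, a shorter carboxypropyl chain, a longer carboxypentyl chain, and a methyl ester or primary amide in place of the carboxylic acid would each test a different part of the change. As far as these compounds go, it also remains open whether the step depends on the neighbouring 2-carboxyethyl group, or whether an amine at the chain end would be tolerated at this position.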